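Swapping Naphthalen-2-yl for 3-Chlorophenyl: Expected Potency

The source may report more compounds than this note shows. Statements on the series, on what has been measured and on what is new or still open speak of the compounds shown alone.

Compound 1, `CCCSc1nc(N/N=C/c2ccc(C)cc2)c2nnn(Cc3ccccc3)c2n1`, gives in a functional assay on MGC-803 cells (Homo sapiens) for antiproliferative activity, read by MTT assay, with a stated time of 72 h (on this read-out lower numbers stand for stronger inhibition and higher numbers for weaker inhibition), a value that is only a limit of the assay: > 64000 nM.
Compound 2, `CCCSc1nc(N/N=C/c2ccc(N(C)C)cc2)c2nnn(Cc3ccccc3)c2n1`, gives in this assay 13100 nM.
Compound 3, `CCCSc1nc(N/N=C/c2ccc3ccccc3c2)c2nnn(Cc3ccccc3)c2n1`, gives in this assay again only a limit of the assay: > 64000 nM.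

Compound 3 therefore stands at the top of what this assay can report, sharing that position with one other compound: the limit of > 64000 nM in this assay, at which 2 of the 3 values shown sit. Compound 4, `CCCSc1nc(N/N=C/c2cccc(Cl)c2)c2nnn(Cc3ccccc3)c2n1`, differs from it in one place: 3-chlorophenyl in place of naphthalen-2-yl on a carbon with a double bond to nitrogen. Among the compounds with values here, no measured step touches 3-chlorophenyl directly. The step of an at least 4.8-fold higher number from compound 2 to compound 3 (0.68 log units; beyond the scatter) shows that moving away from the dimethylamino-bearing ring to naphthalen-2-yl costs at least a modest amount, while a step that the two limits leave unreadable from compound 1 to compound 3 cannot be sized. Within the data shown here, compound 1, carrying a methyl-bearing phenyl ring, also sits at the limit, so the only ring that gave a readable number is the one in compound 2. Compound 4 lacks that dimethylamino group, and the expectation is that it stays near the limit, with an expected step of an at least 1.2-fold lower number from compound 3 to compound 4 (0.10 log units; that floor lies within the scatter) that may not be readable. The estimate for compound 4 is 50000 nM, ranging from 15000 nM to 150000 nM.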

Compound 4, half-maximal inhibitory concentration: > 64000 nM
Compound 4: only a limit was reported; the forecaster's own chance of this, stated with the estimate: 60%; middle value at least 1.2-fold (0.10 log units) from the limit.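

In this assay, 3-chlorophenyl on this carbon gives no readable number, and compound 4 joins the compounds reported only as a limit: the limit of > 64000 nM in this assay, at which 3 of the 4 values shown sit.

Putting 3-chlorophenyl in place of 4-(dimethylamino)phenyl gives an at least 4.8-fold higher number from compound 2 to compound 4 (0.68 log units; beyond the scatter), so among the four rings shown, 4-(dimethylamino)phenyl remains the only one with a readable number. The steps to compound 4 from compound 1 and from compound 3 join two limits and cannot be read, so the rings of these three compounds cannot be ranked against one another.

The compounds shown leave open whether the readable number of compound 2 is special to dimethylamino or would also appear with a phenyl ring carrying a diethylamino or methoxy group. They also leave open whether any change at this place could lower the number further than in compound 2.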